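Swapping pyridin-4-yl for phenyl in the series

The source may report more compounds than this note shows. Statements on the series, on what has been measured and on what is new or still open speak of the compounds shown alone.

In a functional assay on NCI-H1993 cells (Homo sapiens) for inhibition, read by CCK-8 assay, with a stated time of 72 h (a lower number here means a stronger inhibitor, a higher number a weaker inhibitor), compound 1 `CC(NC/N=C/c1cnn(C)c1)c1ccc2ncccc2c1` gives 197 nM, and compound 2 `CC(NC/N=C/c1ccncc1)c1ccc2ncccc2c1` gives 614 nM, the higher of the two numbers. Compound 3 `CC(NC/N=C/c1ccccc1)c1ccc2ncccc2c1` carries phenyl in place of pyridin-4-yl on a carbon with a double bond to nitrogen. Among the compounds with values here, only one measured step bears on this carbon, a 3.1-fold higher number from compound 1 to compound 2 (0.49 log units; beyond the scatter). It shows that a swap at this place can move the number, but it involves a different pair of groups and gives no direction for phenyl. The estimated step is a 1.2-fold lower number from compound 2 to compound 3 (0.09 log units; within the scatter), with nothing beyond the scatter expected. Compound 3 is expected at 500 nM, with an estimated range of 190 nM to 1200 nM.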

Compound 3, half-maximal inhibitory concentration: 1220 nM
Estimate against measurement, compound 3: 2.4-fold (0.39 log units) below, outside the stated range (above it).
By their numbers in this assay, from the lowest: compound 1; then compounds 2 and 3 (each within the scatter of the next).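

Phenyl and pyridin-4-yl on this carbon are not separated in this assay (in this pair, a 2.0-fold higher number from compound 2 to compound 3 (0.30 log units; within the scatter)), so replacing the ring nitrogen of pyridin-4-yl with carbon has no effect that can be told from the scatter. The 1-methyl-1H-pyrazol-4-yl of compound 1 remains the best group shown here, and phenyl in its place gives the largest step in the set (in this pair, a 6.2-fold higher number from compound 1 to compound 3 (0.79 log units; beyond the scatter)). Nothing on hand accounts for these steps.

Still open, from the compounds shown here alone, is whether an amine on the phenyl, or a longer chain in place of the methyl of 1-methyl-1H-pyrazol-4-yl, would move the number in either direction.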